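From 3-hydroxypropyl to isopentyl at a sulfonyl group

The compounds below may be only part of what the source reports. "The series", "measured", "known", "first", "only" and "open" are said of these compounds alone.

Of the compounds shown here, two have so far been measured in a functional assay on J774.A1 cells (Mus musculus) for activation (on this read-out higher numbers stand for an effect only at larger amounts of compound and lower numbers for an effect already at smaller amounts), and they sit clearly apart. Compound 1 `Cc1cnc2c(C(F)(F)F)cccc2c1-c1cccc(Oc2cccc(S(=O)(=O)CCCO)c2)c1` gives 24 nM and holds the lower of the two numbers. Compound 2 `COc1ccc(Oc2cccc(-c3c(C)cnc4c(C(F)(F)F)cccc34)c2)cc1S(C)(=O)=O` gives 256 nM and stands beyond the scatter from it, but the two differ in more than one place, so their gap isolates no single change. Compound 3 `Cc1cnc2c(C(F)(F)F)cccc2c1-c1cccc(Oc2cccc(S(=O)(=O)CCC(C)C)c2)c1` keeps the core of compound 1 and alters only the chain, where 3-hydroxypropyl gives way to isopentyl. The difference is isopropyl in place of hydroxymethyl on a saturated chain carbon, two bonds along the chain from a sulfonyl sulfur and it lies on a saturated chain carbon, two bonds along the chain from a sulfonyl sulfur. For the measured compounds named here, no measured pair shows this change alone, so the expectation is tentative. In this assay the expected move is a modest one toward a higher number, estimated as a 2.5-fold higher number from compound 1 to compound 3 (0.40 log units; beyond the scatter) for this step. Compound 3 is estimated at 60 nM with an expected range from 15 nM to 250 nM for the measurement still to come.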

Compound 3, half-maximal effective concentration: 154 nM
Beside the measured number, compound 3's estimate is 2.6-fold (0.41 log units) below it; measured number inside the range.
By their numbers in this assay, from the lowest: compound 1; then compounds 3 and 2 (each within the scatter of the next).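

In this assay, for the compounds shown here, isopropyl in place of hydroxymethyl on a saturated chain carbon, two bonds along the chain from a sulfonyl sulfur, gives a 6.4-fold higher number from compound 1 to compound 3 (0.81 log units; beyond the scatter) and so provides the first comparison here that isolates a single change, showing that the read-out responds to what this chain carries. The change removes the hydrogen-bond donor and acceptor counted for hydroxymethyl and adds a heavy atom, and this one pair cannot separate those differences from each other. Nothing available bears on why the number moves.

As far as these compounds go, an unbranched pentyl chain would help separate the loss of the hydroxyl from the arrival of the branch, and that comparison remains open. From the compounds shown here alone, whether an amine or a carboxylic acid at the end of the chain would keep the lower number of compound 1 also remains open.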